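This account rests on a few compounds, and the source may have more. Where it says the series, first, only, none or still open, it means among the compounds named here.

Notes on the series. Three compounds carry measured numbers, and they differ from one another only in the substituents hung on the shared core. In a functional assay on A498 cells (Homo sapiens) for inhibition, read by sulforhodamine B assay, with a stated time of 48 h (a lower number here means a stronger inhibitor of growth, a higher number a weaker inhibitor of growth), compound 1 `O=C(Nc1cccc(-n2cc(-c3ccncc3)c(-c3ccc(Cl)c(O)c3)n2)c1)Nc1ccc(Cl)c(Cl)c1` gives 940 nM, the highest of the three numbers seen so far. Compound 2 `COc1cc(-c2nn(-c3cccc(NC(=O)c4cccc(C(F)(F)F)c4)c3)cc2-c2ccncc2)ccc1Cl` gives 687 nM in this assay, within the scatter of compound 1, whereas compound 3 `COc1cc(-c2nn(-c3cccc(NC(=O)c4ccccc4)c3)cc2-c2ccncc2)ccc1Cl` gives 361 nM, which lies beyond the scatter from compound 1. Among the compounds with values here, the one single-point step measured, a 1.9-fold lower number from compound 2 to compound 3 (0.28 log units; within the scatter), stayed within the scatter.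

Compound 4 `O=C(Nc1cccc(-n2cc(-c3ccncc3)c(-c3ccc(Cl)c(O)c3)n2)c1)Nc1ccc(Cl)c(C(F)(F)F)c1` differs from compound 1 by trifluoromethyl in place of chloro on an aromatic carbon. Within the data shown here, no measured pair carries exactly this exchange. Among the measured compounds shown here, the only step that touches on a trifluoromethyl group, a 1.9-fold lower number from compound 2 to compound 3 (0.28 log units; within the scatter), was made on a different part of the series and moved the number by no more than the scatter, so it offers weak guidance. From this, no step beyond the scatter is expected for compound 4 in this assay, in either direction. The step expected is a 1.0-fold lower number from compound 1 to compound 4 (0.02 log units; within the scatter). Compound 4 is therefore estimated at 900 nM, with a range from 400 nM to 2000 nM.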

Compound 4, concentration for 50% growth inhibition: 1400 nM
Estimate against measurement, compound 4: 1.6-fold (0.19 log units) below; the measured number falls inside the stated range.
By their numbers in this assay, from the lowest: compounds 3, 2, 1 and 4 (each within the scatter of the next, the first and the last beyond it).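

At the position held by chloro in the 3,4-dichlorophenyl group, trifluoromethyl gives a 1.5-fold higher number from compound 1 to compound 4 (0.17 log units; within the scatter) in this assay, so this exchange of one heavy atom for four, ortho to a chloro group, produces no step beyond the scatter. With a 1.9-fold lower number from compound 2 to compound 3 (0.28 log units; within the scatter), read on a different part of the series and for a different exchange, both steps involving trifluoromethyl on an aromatic carbon now stay within the scatter. No available measurement bears on what lies behind this result.

Going by these compounds, it remains open whether an amine, a carboxylic acid or a longer alkyl chain at this position would give a step beyond the scatter. On these data alone, it is also open whether the chloro to trifluoromethyl exchange would read the same with methoxy in place of the hydroxy group of compound 1.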